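The source may report more compounds than this note shows. Statements on the series, on what has been measured and on what is new or still open speak of the compounds shown alone.

Measured so far in a physicochemical assay for solubility, read by nephelometry, measured as kinetic solubility, with a stated time of 30 min; a higher number here means a more soluble compound, a lower number a less soluble compound:

Compound 1, `CC(C)(CN)Oc1ccc([C@H]2CC[C@]3(CC2)OOC2(O3)C3CC4CC(C3)CC2C4)cc1`, gives > 100 ug/mL, a limit of the assay.
Compound 2, `CS(=O)(=O)N1CCN(CCCOc2ccc([C@H]3CC[C@]4(CC3)OOC3(O4)C4CC5CC(C4)CC3C5)cc2)CC1`, gives < 1.6 ug/mL, also a limit.
Compound 3, `CC1(C)CC(O)(COc2ccc([C@H]3CC[C@]4(CC3)OOC3(O4)C4CC5CC(C4)CC3C5)cc2)CC(C)(C)N1`, gives > 100 ug/mL, again a limit.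

Compound 1 therefore stands at the limit of > 100 ug/mL in this assay, at which 2 of the 3 values shown sit, and no number is read for it. Compound 4, `NC1CCN(S(=O)(=O)c2ccc([C@H]3CC[C@]4(CC3)OOC3(O4)C4CC5CC(C4)CC3C5)cc2)CC1`, is not yet measured; it differs from compound 1 by (4-aminopiperidin-1-yl)sulfonyl in place of 1-(aminomethyl)-1-methylethoxy on an aromatic carbon.

Going by the values given here, two measured steps touch the same aromatic oxygen position. The step that the two limits leave unreadable from compound 1 to compound 3 runs between two limits and its size cannot be read. Among the compounds with values here, the step of an at least 62-fold higher number from compound 2 to compound 3 (1.79 log units; beyond the scatter) is large, and it is the only step here that reaches a number beyond the scatter; it shows that a substituent at this position can move the value between the two limits, with compound 2 sitting at the limit of < 1.6 ug/mL in this assay, at which 1 of the 3 values shown sits. Within the data shown here, no step exchanges the oxygen-linked chain for a sulfonyl-linked ring, so the step to compound 4 is not directly covered. Compound 4 is estimated at 30 ug/mL, in the range 5 ug/mL to 100 ug/mL. The step expected is an at least 3.3-fold lower number from compound 1 to compound 4 (0.52 log units; beyond the scatter), a fall from the upper limit but not to the lower one.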

Compound 4, solubility: 12.5 ug/mL
Beside the measured number, compound 4's estimate is 2.4-fold (0.38 log units) above it; measured number inside the range.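

In this assay, going by these compounds alone, compound 4 gives 12.5 ug/mL, the first value that is a number and not a limit of the assay. Placing (4-aminopiperidin-1-yl)sulfonyl in place of 1-(aminomethyl)-1-methylethoxy on the aromatic carbon gives an at least 8.0-fold lower number from compound 1 to compound 4 (0.90 log units; beyond the scatter), so a change at this position can bring the value off the upper limit without taking it to the lower one. Compound 1 is held at a limit, so this step gives only a bound on its size: the limit of > 100 ug/mL in this assay, at which 2 of the 4 values shown sit.

The exchange alters the sulfonyl link and the ring together, so the compounds shown leave the part played by each open. Also open, going by these compounds, is how the value would respond to a carbonyl in place of the sulfonyl, or to a carboxylic acid in place of the amine on the piperidine.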